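The source may report more compounds than this note shows. Statements on the series, on what has been measured and on what is new or still open speak of the compounds shown alone.

Measured so far in a functional assay on BJAB cells (Homo sapiens) for antiproliferative activity, with a stated time of 4 days; a higher number here means that more compound is needed for the effect, a lower number that less compound is needed:
- compound 1, `Cc1ccc(-c2c(C)nn(-c3nc(-c4ccc(Cl)c(Cl)c4)c(SC(C)C)s3)c2C(=O)O)cc1`, gives 3800 nM
- compound 2, `COc1cc(-c2c(C)nn(-c3nc(-c4ccc(Cl)c(Cl)c4)c(SC(C)C)s3)c2C(=O)O)cc(C(F)(F)F)c1`, gives 1380 nM
- compound 3, `COc1cncc(-c2c(C)nn(-c3nc(-c4ccc(Cl)c(Cl)c4)c(SC(C)C)s3)c2C(=O)O)c1`, gives 21000 nM

Among these three, compound 3 gives the highest number, so it needs the most compound for the effect: one step is a 5.5-fold higher number from compound 1 to compound 3 (0.74 log units; beyond the scatter), and the other is a 15-fold higher number from compound 2 to compound 3 (1.18 log units; beyond the scatter). Both steps replace the 4-methylphenyl or the 3-methoxy-5-(trifluoromethyl)phenyl with the 5-methoxypyridin-3-yl, and each time the number rose well beyond the scatter.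

Compound 4, `Cc1nn(-c2nc(-c3ccc(Cl)c(Cl)c3)c(SC(C)C)s2)c(C(=O)O)c1-c1cccc(C(F)(F)F)c1`, is not yet measured. It differs from compound 3 in one place: 3-(trifluoromethyl)phenyl in place of 5-methoxypyridin-3-yl on an aromatic carbon. This move goes the other way from those two steps, back from the pyridinyl to a phenyl ring that carries a trifluoromethyl group, as in compound 2, but without the methoxy group. Because the steps of a 5.5-fold higher number from compound 1 to compound 3 (0.74 log units; beyond the scatter) and a 15-fold higher number from compound 2 to compound 3 (1.18 log units; beyond the scatter) were both sizeable, a clearly lower number is expected for compound 4 in this assay, a step of about a 9.5-fold lower number from compound 3 to compound 4 (0.98 log units; beyond the scatter). The estimate for compound 4 is 2200 nM, with a range from 700 nM to 7000 nM.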

Compound 4, half-maximal effective concentration: 22000 nM
Beside the measured number, compound 4's estimate is 10-fold (1.00 log units) below it, outside the stated range (above it).
By their numbers in this assay, from the lowest: compound 2; then compound 1; then compounds 3 and 4 (each within the scatter of the next).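

Swapping the 5-methoxypyridin-3-yl for 3-(trifluoromethyl)phenyl at this position gives a 1.0-fold higher number from compound 3 to compound 4 (0.02 log units; within the scatter) in this assay so a carbon-only ring carrying a trifluoromethyl group is not enough on its own to lower the number. Compound 2 has the same trifluoromethyl group plus a methoxy group, and replacing that methoxy with hydrogen gives a 16-fold higher number from compound 2 to compound 4 (1.20 log units; beyond the scatter) which shows, in these compounds, that the low number of compound 2 needs the methoxy group on that ring too. The step of a 5.8-fold higher number from compound 1 to compound 4 (0.76 log units; beyond the scatter) adds that this trifluoromethyl ring does no better here than the simpler 4-methylphenyl.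

Going by these compounds, whether a phenyl ring with only a methoxy group, or with an amine or an ethoxy group in its place, would also give a low number remains open. Nothing shown here explains why these changes have the effects they do.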